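The source may report more compounds than this note shows. Statements on the series, on what has been measured and on what is new or still open speak of the compounds shown alone.

Within the data shown here, in a functional assay (muscle tissue) with Cavia porcellus as the target (a lower number here means that less compound is needed, a higher number that more compound is needed for the effect), compound 1 (`COC(=O)C1=C(C)N=C(C)/C(=C(\O)OC)C1c1cccc(Br)c1`) gives 1.29 nM in the series so far. Compound 2 (`COC(=O)C1=C(C)N=C(C)/C(=C(\O)OC)C1c1cc([N+](=O)[O-])ccc1O`) gives 100 nM and so holds the higher of the two numbers, with a gap to compound 1 that lies beyond the usual scatter. The next entry is compound 3 (`COC(=O)C1=C(C)N=C(C)/C(=C(\O)OC)C1c1cccc([N+](=O)[O-])c1`), still unmeasured. Going from compound 2 to compound 3, hydrogen in place of hydroxy on an aromatic carbon describes the change: hydrogen in place of hydroxy on an aromatic carbon, ortho to a large group and para to a nitro group. The nitro group itself stays.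

Among the measured compounds shown here, no measured pair isolates this exchange, so the expectation rests on two compounds that also differ elsewhere. Compound 1 at 1.29 nM has no hydroxy on its aromatic ring, and compound 3 shares that feature. A clear fall in the number in this assay is therefore expected, beyond the scatter, and compound 3 is not expected to fall quite as low as compound 1. The expected step is a 25-fold lower number from compound 2 to compound 3 (1.40 log units; beyond the scatter) in this estimate. For compound 3 the estimated value is 4 nM (expected range 1 nM to 16 nM) in this assay.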

Compound 3, half-maximal effective concentration: 3.98 nM
For compound 3 the middle estimate is 1.0-fold (0.00 log units) above the measured one, within the range that was stated.
By their numbers in this assay, from the lowest: compound 1; then compound 3; then compound 2.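

In this assay, the hydroxy on the aromatic carbon, ortho to a large group and para to a nitro group, can now be read on its own, with the nitro group held constant: hydrogen in its place gives a 25-fold lower number from compound 2 to compound 3 (1.40 log units; beyond the scatter). The same compound also isolates a second exchange, since nitro in place of bromo on an aromatic carbon gives a 3.1-fold higher number from compound 1 to compound 3 (0.49 log units; beyond the scatter), a modest step beyond the scatter, whereas the hydroxy exchange is a large one. In this small set, the hydroxy exchange therefore accounts for most of the wide gap in the assay, and the compounds shown offer no measurement that explains either step.

Still open, on these data alone, is how an amine or a methoxy group on that same aromatic carbon would compare with hydroxy and hydrogen, which would show whether the large step is particular to hydroxy. Also open, as far as these compounds go, is whether the hydroxy step keeps its size with bromo or a nitrile in place of the nitro group, as the present step rests on a single pair.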